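Indole Amide to Chlorophenyl Isoxazole at the Agonist Series

The source may hold more compounds than are shown below. What is called first, only, known or untested is meant among the compounds shown, and "the series" means these compounds.

The measured compounds, each with its result in a functional assay on HEK293 cells for agonist activity at growth hormone secretagogue receptor type 1 (Homo sapiens), read by HTRF and inositol phosphate accumulation, with a stated time of 90 min, in the presence of a further agent that is not named here; a higher number here means a larger maximal response, a lower number a smaller maximal response:
- compound 1, `Cc1ccc2[nH]c(C(=O)N[C@H]3CN(S(=O)(=O)c4ccccc4)C[C@@H]3C(=O)NCCN(C)C)cc2c1`: compound 1 gives 93%
- compound 2, `Cc1ccc2[nH]c(C(=O)N[C@H]3CN(S(=O)(=O)c4ccccc4)C[C@@H]3C(=O)N[C@@H]3CCCNC3)cc2c1`: compound 2 gives 91%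
- compound 3, `Cc1ccc2[nH]c(C(=O)N[C@H]3CN(S(=O)(=O)c4ccccc4)C[C@@H]3C(=O)N[C@H]3CCCNC3)cc2c1`: compound 3 gives 98%

Compound 3 carries the highest of the three numbers in this assay, yet its gaps to the other two lie within the scatter: a number 5 percentage points higher from compound 1 to compound 3 (within the scatter) and a number 7 percentage points higher from compound 2 to compound 3 (within the scatter), the latter being a pair that differ only in configuration as drawn (the fact that compounds 2 and 3 differ only in the configuration as drawn). Likewise a number 2 percentage points lower from compound 1 to compound 2 (within the scatter) changes nothing beyond the scatter. Every measured step therefore concerns the amide-type nitrogen on the far side of the shared core, and all leave the maximal response essentially flat.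

Compound 4, `O=C(N[C@H]1CN(S(=O)(=O)c2ccccc2)C[C@@H]1C(=O)N[C@H]1CCCNC1)c1cc(-c2ccc(Cl)cc2)on1`, takes a different route: 5-(4-chlorophenyl)-1,2-oxazol-3-yl in place of 5-methyl-1H-indol-2-yl on a carbonyl carbon. For the measured compounds named here, no measured step touches this carbonyl carbon, so nothing in the data forecasts the direction of the step in this assay. The account must lean on the flatness seen so far while allowing wider uncertainty for an untested position. Compound 4 is therefore expected to give 85% in this assay, within a range of 45% to 105%, which means an expected step of a number 13 percentage points lower from compound 3 to compound 4 (beyond the scatter).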

Compound 4, largest response reached (Emax), in percent of the reference or control that the assay uses: 91%
Beside the measured number, compound 4's estimate is 6 percentage points below it, and the stated range covers the measured number.
By their numbers in this assay, from the lowest: compounds 2, 4, 1 and 3 (each within the scatter of the next).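

Until this point, every measured step lay on the amide-type nitrogen on the far side of the shared core, whereas here the group on the carbonyl carbon is exchanged, and in this assay the result is within the scatter (a number 7 percentage points lower from compound 3 to compound 4 (within the scatter)). This position therefore accepts 5-(4-chlorophenyl)-1,2-oxazol-3-yl in place of 5-methyl-1H-indol-2-yl without a change in maximal response beyond the scatter, even though a group with 1 hydrogen-bond donor leaves and one with 0 hydrogen-bond donors and 2 hydrogen-bond acceptors enters. Nothing given here bears on why the response holds across this exchange.

From the compounds shown here alone, it remains open whether the response would hold if an amine or a carboxylic acid stood in place of the chlorine of the new group. Also open, going by these compounds, is whether 2-(dimethylamino)ethyl on the amide-type nitrogen would behave alongside 5-(4-chlorophenyl)-1,2-oxazol-3-yl as it does alongside 5-methyl-1H-indol-2-yl.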